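The compounds below may be only part of what the source reports. "The series", "measured", "known", "first", "only" and "open" are said of these compounds alone.

Of the compounds shown here, three have been measured for how much of each MCF7 cells tolerate. Compound 1 `C=CCOC(=O)Nc1ccc([Se]C#N)cc1` carries a selenocyanate on its core and an allyl carbamate. In a functional assay on MCF7 cells (Homo sapiens) for cytotoxicity, read by MTT assay, with a stated time of 72 h (a lower number here means that less compound is tolerated, a higher number that more compound is tolerated), compound 1 gives 71200 nM. Compound 2 `CCCCOC(=O)Nc1ccc([Se][Se]c2ccc(NC(=O)OCCCC)cc2)cc1` is a diselenide built from two carbamate-bearing parts, and in this assay compound 2 gives 75200 nM. Compound 3 `Cc1ccc(OC(=O)Nc2ccc([Se][Se]c3ccc(NC(=O)Oc4ccc(C)cc4)cc3)cc2)cc1` is a diselenide of the same kind with aryl carbamates, and in this assay compound 3 gives 74000 nM. Compound 1 has the smallest of the three numbers, yet its distance to compound 3 and to compound 2 both lie within the usual scatter, so the three compounds cannot be told apart on these numbers.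

Compound 4 `CCCCCCOC(=O)Nc1ccc([Se]C#N)cc1` keeps the selenocyanate and the carbamate of compound 1 and differs from it in one place: pentyl in place of vinyl on a saturated chain carbon bound to an oxygen next to a carbonyl group. Among the compounds with values here, no pair of measured compounds shows the effect of such a change, and the three measured numbers, whether the carbamate carries a butyl, an aryl or an allyl group, all fall in the same narrow range. The step of a 1.0-fold lower number from compound 1 to compound 4 (0.01 log units; within the scatter) is therefore expected to be none beyond the scatter. In this assay compound 4 is expected to give 70000 nM, within a range from 35000 nM to 140000 nM.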

Compound 4, concentration lethal to 50% of the cells: 63900 nM
The estimate for compound 4 lay 1.1-fold (0.04 log units) above the measured number, within the range that was stated.
By their numbers in this assay, from the lowest: compounds 4, 1, 3 and 2 (each within the scatter of the next).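

Within the data shown here, until now no two measured compounds differed in just one place, so this is the first direct look at a change on a saturated chain carbon bound to an oxygen next to a carbonyl group. In this assay, pentyl in place of vinyl there gives a 1.1-fold lower number from compound 1 to compound 4 (0.05 log units; within the scatter), so this pair cannot be told apart even though the same difference, read one bond further out as allyl to hexyl, lengthens the chain and removes the double bond outside aromatic rings. Nothing available here gives a measured explanation for this result.

The compounds shown leave open whether a longer chain such as decyl, or a chain ending in an amine or a carboxylic acid, would also give a number within the scatter of these two. Among these compounds, they also include no pair differing only in having a selenocyanate or a diselenide, so what that part contributes to the number in this assay stays unanswered.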